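The source may hold more compounds than are shown below. What is called first, only, known or untested is meant among the compounds shown, and "the series" means these compounds.

Measured so far in a functional assay on HCT-116 cells (Homo sapiens) for antiproliferative activity, read by radiometric assay, with a stated time of 72 h; a lower number here means a stronger inhibitor, a higher number a weaker inhibitor:
compound 1 `O=C(CCCCCCC(=O)Nc1cc2ncnc(Nc3ccc(Cl)cc3F)c2s1)NO` at 1790 nM
compound 2 `Cc1ccc(F)c(Nc2ncnc3cc(NC(=O)CCCCCCC(=O)NO)sc23)c1` at 1330 nM
compound 3 `COc1ccc(Nc2ncnc3cc(NC(=O)CCCCCCC(=O)NO)sc23)c(C)c1` at 2480 nM

Compound 1 sits within the scatter of both other compounds. The two steps from it are a 1.3-fold lower number from compound 1 to compound 2 (0.13 log units; within the scatter) and a 1.4-fold higher number from compound 1 to compound 3 (0.14 log units; within the scatter), so no order can be read among these values. The remaining step, a 1.9-fold higher number from compound 2 to compound 3 (0.27 log units; within the scatter), is also within the scatter.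

The next compound is compound 4 `C#Cc1cccc(Nc2ncnc3cc(NC(=O)CCCCCCC(=O)NO)sc23)c1`, which keeps the core of compound 1. The change is 3-ethynylphenyl in place of 4-chloro-2-fluorophenyl on a nitrogen on an aromatic ring. All three measured steps exchange the group at this same place, so they are the relevant precedents. Among the measured compounds shown here, none of the measured compounds carries 3-ethynylphenyl, so the group itself is untested in this assay. On those precedents, no step beyond the scatter is expected, in either direction. The estimated step, a 1.1-fold lower number from compound 1 to compound 4 (0.05 log units; within the scatter), is expected to stay within the scatter. For compound 4 the expected value is 1600 nM, with an estimated range of 700 nM to 3500 nM.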

Compound 4, half-maximal inhibitory concentration: 1010 nM
For compound 4 the middle estimate is 1.6-fold (0.20 log units) above the measured one, within the range that was stated.
By their numbers in this assay, from the lowest: compounds 4, 2, 1 and 3 (each within the scatter of the next, the first and the last beyond it).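

With 3-ethynylphenyl on the nitrogen, the series gains a group carrying a triple bond outside aromatic rings and no halogen, and in this assay this exchange stays within the scatter against two earlier groups (a 1.8-fold lower number from compound 1 to compound 4 (0.25 log units; within the scatter); a 1.3-fold lower number from compound 2 to compound 4 (0.12 log units; within the scatter)). Among the compounds shown here, the same group gives the first step beyond the scatter, though a modest one (a 2.5-fold lower number from compound 3 to compound 4 (0.39 log units; beyond the scatter)), so the aryl group at this place can shift the number, but only between the two ends of the set. No measurement shown accounts for this step.

Going by these compounds, whether an amine or a carboxylic acid on this phenyl ring would give a larger step remains open. All four compounds share one chain, so a shorter or longer chain is also untested here.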